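The source may hold more compounds than are shown below. What is called first, only, known or untested is meant among the compounds shown, and "the series" means these compounds.

The measured compounds in a functional assay on CHO cells for agonist activity at Free fatty acid receptor 1 (Homo sapiens), read by FLIPR and calcium flux, tested at 100 nM; a lower number here means a weaker effect, a higher number a stronger effect of the compound at the concentration tested:
Compound 1 `Cc1nc(-c2cccc3ccccc23)sc1COc1ccc2c(c1)OCC2CC(=O)O` gives 8.53%.
Compound 2 `Cc1nc(-c2ccc(Cl)cc2)sc1COc1ccc2c(c1)OCC2CC(=O)O` gives 53.4%.
Compound 3 `Cc1nc(-c2cccc(F)c2)sc1COc1ccc2c(c1)OCC2CC(=O)O` gives 56.9%.

Compound 3 holds the highest of the three numbers in this assay, but its gap to compound 2 is within the scatter, a number 3.5 percentage points higher from compound 2 to compound 3 (within the scatter), so those two cannot be ordered; its gap to compound 1 is beyond it, a number 48.4 percentage points higher from compound 1 to compound 3 (beyond the scatter). Compound 4 `Cc1nc(-c2ccc(F)cc2)sc1COc1ccc2c(c1)OCC2CC(=O)O` is not yet measured. It differs from compound 3 in one place: 4-fluorophenyl in place of 3-fluorophenyl on an aromatic carbon. Going by the values given here, no measured step moves a fluorine around the same ring. Among the compounds with values here, the steps that bear on it are a number 44.9 percentage points higher from compound 1 to compound 2 (beyond the scatter), a number 48.4 percentage points higher from compound 1 to compound 3 (beyond the scatter) and a number 3.5 percentage points higher from compound 2 to compound 3 (within the scatter), which show that a 4-chlorophenyl and a 3-fluorophenyl give much the same number. Compound 4 is therefore expected to show a step within the scatter, a number 2.9 percentage points lower from compound 3 to compound 4 (within the scatter). The value estimated for compound 4 in this assay is 54%, with a range from 38% to 70%.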

Compound 4, a percentage reported as activity, at one concentration (the size of the read-out at that concentration, not a potency): 61.6%
The estimate for compound 4 lay 7.6 percentage points below the measured number, and the stated range covers the measured number.
By their numbers in this assay, from the lowest: compound 1; then compounds 2, 3 and 4 (each within the scatter of the next).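

In this assay, the 4-fluorophenyl in place of the 3-fluorophenyl gives a number 4.7 percentage points higher from compound 3 to compound 4 (within the scatter), and fluoro in place of chloro gives a number 8.2 percentage points higher from compound 2 to compound 4 (within the scatter), so among these compounds neither change separates the values at this position. Going by these compounds alone, the only large change remains the one away from naphthalen-1-yl, now also seen as a number 53.1 percentage points higher from compound 1 to compound 4 (beyond the scatter). No evidence on the origin of these steps is available. The compounds shown leave open whether a phenyl ring carrying an amine or a methoxy group at this position would stay with compounds 2, 3 and 4 or fall towards compound 1.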